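Shifting a Trifluoromethyl Group on Two Related Cores

The source may hold more compounds than are shown below. What is called first, only, known or untested is meant among the compounds shown, and "the series" means these compounds.

Measured in a functional assay on HCT-15 cells (Homo sapiens) for inhibition; on this read-out higher numbers stand for weaker inhibition and lower numbers for stronger inhibition:
Compound 1 `Oc1ccccc1-c1cc(-c2cccc(C(F)(F)F)c2)cc(-c2ccccc2O)n1` gives > 50000 nM, which is a limit of the assay and not a number.
Compound 2 `Oc1ccccc1-c1cc(-c2ccc(C(F)(F)F)cc2)cc(-c2ccccc2O)n1` gives > 50000 nM, again a limit of the assay rather than a number.
For the measured compounds named here, compound 3 `Oc1cccc(-c2cc(-c3cccc(C(F)(F)F)c3)cc(-c3cccc(O)c3)n2)c1` gives 13600 nM, the only number among the three.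

The difference between the core of compound 1 and the core of compound 3 is not broken down here. Compound 1 and compound 2 differ by 4-(trifluoromethyl)phenyl in place of 3-(trifluoromethyl)phenyl on an aromatic carbon. As far as these compounds go, the step that the two limits leave unreadable from compound 1 to compound 2 cannot be read because the limit of > 50000 nM in this assay, at which 2 of the 3 values shown sit, holds both values, so the size of that step is unknown.

Compound 4 `Oc1cccc(-c2cc(-c3ccc(C(F)(F)F)cc3)cc(-c3cccc(O)c3)n2)c1` has not yet been measured. It differs from compound 3 by 4-(trifluoromethyl)phenyl in place of 3-(trifluoromethyl)phenyl on an aromatic carbon. This is the same kind of change as that from compound 1 to compound 2, but the surroundings of the place differ: around compound 4 the place is meta to two 3-hydroxyphenyl groups, whereas around compound 2 it is meta to two 2-hydroxyphenyl groups.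

Going by the values given here, since the only earlier example of this change left no readable step, the expectation for compound 4 rests mainly on the value of compound 3 in this assay, which is 13600 nM. The step from compound 3 to compound 4 is expected to be a 1.5-fold higher number from compound 3 to compound 4 (0.17 log units; within the scatter), with wide uncertainty. Compound 4 is therefore estimated at 20000 nM in this assay, expected to lie between 5000 nM and 60000 nM.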

Compound 4, half-maximal inhibitory concentration: > 50000 nM
Compound 4: no number, only a limit; the forecaster's own chance of this, stated with the estimate: 35%; middle value at least 2.5-fold (0.39 log units) from the limit.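

In this assay, as far as these compounds go, 4-(trifluoromethyl)phenyl in place of 3-(trifluoromethyl)phenyl on the core of compound 3 gives an at least 3.6-fold higher number from compound 3 to compound 4 (0.56 log units; beyond the scatter), so on this core the change weakens inhibition, by an amount whose upper end is unknown. Compound 4 gives > 50000 nM, which is a limit of the assay and not a number. The same change on the core of compound 1 cannot be read, so the series shows its effect on one core only and does not show whether that effect carries from one core to the other, because both compounds of that pair are held at the same limit: the limit of > 50000 nM in this assay, at which 3 of the 4 values shown sit.

The compounds shown leave open whether another group at the same place on the core of compound 3, such as a nitrile, a methoxy group or an amine carried on the phenyl ring in place of trifluoromethyl, would give a readable value in this assay. They also leave open how the result would change if a carboxylic acid or an amine stood in place of the hydroxy groups on the two 3-hydroxyphenyl groups of compound 3.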